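The source may hold more compounds than are shown below. What is called first, only, known or untested is meant among the compounds shown, and "the series" means these compounds.

Measured so far:
compound 1 `O=C1/C(=C/c2ccccc2F)CN(S(=O)(=O)c2ccc(O[N+](=O)[O-])cc2)C/C1=C\c1ccccc1F`: 15500 nM
compound 2 `O=C1/C(=C/c2ccccc2F)CN(S(=O)(=O)c2ccc(Cl)cc2)C/C1=C\c1ccccc1F`: 14100 nM
compound 3 `N#Cc1ccc(S(=O)(=O)N2C/C(=C\c3ccccc3F)C(=O)/C(=C/c3ccccc3F)C2)cc1`: 11000 nM

In an ADME assay on L02 cells (Homo sapiens) for cytotoxicity, read by MTT assay, with a stated time of 24 h (on this read-out higher numbers stand for weaker inhibition and lower numbers for stronger inhibition), compound 3 gives the lowest of these three numbers, but its gaps to the others stay within the scatter: a 1.3-fold lower number from compound 2 to compound 3 (0.11 log units; within the scatter) and a 1.4-fold lower number from compound 1 to compound 3 (0.15 log units; within the scatter). Compound 4 `CC(=O)Nc1ccc(S(=O)(=O)N2C/C(=C\c3ccccc3F)C(=O)/C(=C/c3ccccc3F)C2)cc1` differs from compound 3 in one place: acetamido in place of cyano on an aromatic carbon. The three steps that bear on this all exchange a small group on the same aromatic carbon, and none moved the number beyond the scatter: a 1.1-fold lower number from compound 1 to compound 2 (0.04 log units; within the scatter), a 1.4-fold lower number from compound 1 to compound 3 (0.15 log units; within the scatter), a 1.3-fold lower number from compound 2 to compound 3 (0.11 log units; within the scatter). For the measured compounds named here, no measured step involves acetamido itself. The expected step is therefore small, a 1.1-fold higher number from compound 3 to compound 4 (0.06 log units; within the scatter), with no direction beyond the scatter. The estimate for compound 4 in this assay is 12500 nM, with a range from 6000 nM to 26000 nM.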

Compound 4, half-maximal inhibitory concentration: 11500 nM
Estimate against measurement, compound 4: 1.1-fold (0.04 log units) above, and the stated range covers the measured number.
By their numbers in this assay, from the lowest: compounds 3, 4, 2 and 1 (each within the scatter of the next).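

In this assay, acetamido carries an amide hydrogen that cyano lacks, yet every new step stays within the scatter (a 1.0-fold higher number from compound 3 to compound 4 (0.02 log units; within the scatter)) (a 1.2-fold lower number from compound 2 to compound 4 (0.09 log units; within the scatter)) (a 1.3-fold lower number from compound 1 to compound 4 (0.13 log units; within the scatter)). Nitrooxy, chloro, cyano and acetamido on this aromatic carbon therefore give numbers that cannot be told apart, so this position has so far tolerated each exchange shown. No measurement shown here offers a reason for this flat result. From the compounds shown here alone, whether an amine or a carboxylic acid on this carbon would move the number beyond the scatter remains open. So does the effect of any change to the shared core.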